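The source may report more compounds than this note shows. Statements on the series, on what has been measured and on what is new or still open speak of the compounds shown alone.

Compound 1 `COc1cc(-c2nn(-c3cccc(NC(=O)c4cccc(C(F)(F)F)c4)c3)cc2-c2ccncc2)ccc1Cl` was measured in a functional assay on TK-10 cells (Homo sapiens) for inhibition, read by sulforhodamine B assay, with a stated time of 48 h (on this read-out higher numbers stand for weaker inhibition of growth and lower numbers for stronger inhibition of growth), and gave only a limit, > 50000 nM.
Compound 2 `COc1cc(-c2nn(-c3cccc(NC(=O)Nc4ccc(Cl)c(Cl)c4)c3)cc2-c2ccncc2)ccc1Cl` gave a number in this assay, 40900 nM.
Compound 3 `O=C(Nc1cccc(-n2cc(-c3ccncc3)c(-c3ccc(Cl)c(O)c3)n2)c1)Nc1ccc(Cl)c(Cl)c1` again gave only a limit in this assay, > 32500 nM.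

Compound 3 therefore stands at a limit of this assay rather than at a number, the limit being (the limit of > 32500 nM in this assay, at which 1 of the 3 values shown sits). The step from compound 1 to compound 2, an at least 1.2-fold lower number from compound 1 to compound 2 (0.08 log units; that floor lies within the scatter), runs from another limit, (the limit of > 50000 nM in this assay, at which 1 of the 3 values shown sits), and stays within the scatter. The step that the limit leaves unreadable from compound 2 to compound 3 cannot be sized.

Compound 4 `O=C(Nc1cccc(-n2cc(-c3ccncc3)c(-c3ccc(Cl)c(O)c3)n2)c1)Nc1ccc(Cl)c(C(F)(F)F)c1` differs from compound 3 in one place: trifluoromethyl in place of chloro on an aromatic carbon. Within the data shown here, the only measured step that touches the same region is an at least 1.2-fold lower number from compound 1 to compound 2 (0.08 log units; that floor lies within the scatter), which exchanged one aryl group on the urea side for another and did not move the read-out beyond the scatter. On that basis no change beyond the scatter is expected in this assay, and compound 3 already sits at a limit. Compound 4 is therefore estimated at 40000 nM, in the range 15000 nM to 100000 nM. The expected step is a step that the limit leaves unreadable from compound 3 to compound 4.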

Compound 4, concentration for total growth inhibition: 11900 nM
Estimate against measurement, compound 4: 3.4-fold (0.53 log units) above, and the stated range ends above it.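

In this assay, trifluoromethyl in place of chloro on this aromatic carbon, ortho to a chloro group, gives an at least 2.7-fold lower number from compound 3 to compound 4 (0.43 log units; beyond the scatter), the only readable step shown that lies beyond the scatter. This position on the urea's aryl group therefore responds to a single exchange, which the whole-group aryl change between compound 1 and compound 2 had not shown. The step is only a floor and its full size stays unknown, because compound 3 stands at a limit and not at a number: the limit of > 32500 nM in this assay, at which 1 of the 4 values shown sits.

From the compounds shown here alone, whether a nitrile or a methyl at this position would lower the number as well remains open. So does whether the step would hold with a methoxy in place of the hydroxyl on the other aryl ring, and which property of trifluoromethyl lies behind it.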